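This account rests on a few compounds, and the source may have more. Where it says the series, first, only, none or still open, it means among the compounds named here.

Measured so far in a physicochemical assay for lipophilicity, read by NMR; a lower number here means a more polar compound, a higher number a more lipophilic compound:

- compound 1 `CC[C@H](F)[C@H](C)O`: 0.68
- compound 2 `CC(=O)N1CCC[C@H]1C(=O)OCCF`: -0.43
- compound 3 `CCCC(F)CO`: 0.87

Compound 2 gives the lowest of the three numbers. Its nearest neighbour is compound 1, whose value is higher by a margin beyond the scatter; compound 3 lies further off still, again beyond the scatter. Going by the values given here, no two of the measured compounds differ in one place only, so no single step between measured compounds can be read off; the three values simply show that compound 2 is the most polar of the set.

The next compound, compound 4 `CC(=O)N1CCC[C@H]1C(=O)OCC(F)(F)F`, is not yet measured. It differs from compound 2 in one place: trifluoromethyl in place of fluoromethyl on a saturated chain carbon bound to an oxygen next to a carbonyl group.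

Among the compounds with values here, with no measured pair carrying this change, the expected size of the step rests on the structural difference alone. The expectation is a move toward the higher end of this assay, larger than the scatter, and the step is estimated as a number 0.68 log units higher from compound 2 to compound 4 (beyond the scatter). For compound 4 the estimate is 0.25, with a range from -0.15 to 0.65.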

Compound 4, partition coefficient: 0.55
Beside the measured number, compound 4's estimate is 0.30 log units below it; measured number inside the range.
By their numbers in this assay, from the lowest: compound 2; then compounds 4, 1 and 3 (each within the scatter of the next, the first and the last beyond it).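

Going by these compounds alone, at the saturated chain carbon bound to an oxygen next to a carbonyl group, trifluoromethyl in place of fluoromethyl gives the first step that can be read in one place in this assay: a number 0.98 log units higher from compound 2 to compound 4 (beyond the scatter). The step lies beyond the scatter, so the read-out at this position on the shared core does respond to this exchange of groups. No measurement at hand accounts for the size of the step.

The compounds shown leave open how a difluoromethyl or a plain methyl group at this place would read in this assay, and so whether the step grows evenly with each added fluorine. They also leave open whether the same exchange gives a step of similar size on a different core.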